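The source may hold more compounds than are shown below. What is called first, only, known or untested is meant among the compounds shown, and "the series" means these compounds.

Three compounds of the series carry a measured number. Compound 1 `C=CCc1cc(C(C)=O)c(O)cc1OCCCCCC#N` gives 41% in an assay on isolated protein for binding affinity to leukotriene B4 receptor 1 (Homo sapiens), tested at 1 uM; on this read-out higher numbers stand for more inhibition at the one concentration tested (going by the name of the read-out) and lower numbers for less inhibition; compound 2 `C=CCc1cc(C(C)=O)c(O)cc1OCCCCCCCC#N` gives 52% in this assay; compound 3 `C=CCCCCOc1cc(O)c(C(C)=O)cc1CC=C` gives 27% in this assay. Compound 3 thus stands lowest of the three, and the two measured steps that end there, a number 14 percentage points lower from compound 1 to compound 3 (beyond the scatter) and a number 25 percentage points lower from compound 2 to compound 3 (beyond the scatter), are both beyond the scatter. Within the nitrile chain pair, a number 11 percentage points higher from compound 1 to compound 2 (beyond the scatter).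

Compound 4 `C=CCc1cc(C(C)=O)c(O)cc1OCCCCCC(=O)OC` has not yet been measured. It differs from compound 3 in one place: (methoxycarbonyl)methyl in place of vinyl on a saturated chain carbon, four bonds along the chain from an oxygen on an aromatic ring. The two measured steps bearing on it each replace a chain ending in a nitrile with a vinyl group. Each of them runs lower by a modest amount, so read in the other direction both run upward by a modest amount. The entering (methoxycarbonyl)methyl likewise brings two hydrogen-bond acceptors onto the chain where compound 3 has none, and the reading is taken as a modest rise rather than a fall. The step expected in this assay is a number 13 percentage points higher from compound 3 to compound 4 (beyond the scatter). Compound 4 is therefore estimated at 40%, with a range from 25% to 55%.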

Compound 4, a percentage reported as inhibition, at one concentration (the size of the read-out at that concentration, not a potency): 65%
For compound 4 the middle estimate is 25 percentage points below the measured one, outside the stated range (above it).
By their numbers in this assay, from the lowest: compound 3; then compound 1; then compound 2; then compound 4.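

In this assay, going by these compounds alone, the largest step so far comes at this place on the chain, where (methoxycarbonyl)methyl in place of vinyl gives a number 38 percentage points higher from compound 3 to compound 4 (beyond the scatter) and brings in the 2 hydrogen-bond acceptors counted for the entering group. The ester chain end also exceeds both nitrile chain ends, with a number 13 percentage points higher from compound 2 to compound 4 (beyond the scatter) and a number 24 percentage points higher from compound 1 to compound 4 (beyond the scatter), so the series now runs from the vinyl end through the nitrile ends to the ester end, and compound 4 stands highest of the four by steps all beyond the scatter. Nothing measured here accounts for the size of these rises.

The compounds shown leave open whether the rise belongs to the methyl ester itself or would also appear with a carboxylic acid or a primary amide ending the same chain. They also leave open how the number responds to chain length on the ester side, which a longer chain ending in the same methoxycarbonyl group would address, as the nitrile pair of compound 1 and compound 2 does on its own side.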